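Methoxy for chloro carried from one core to a second

This account rests on a few compounds, and the source may have more. Where it says the series, first, only, none or still open, it means among the compounds named here.

Measured compounds, growth inhibition in a functional assay on cells (Cancer cell lines, Homo sapiens) for cytotoxicity, with a stated time of 48 h; on this read-out lower numbers stand for stronger inhibition of growth and higher numbers for weaker inhibition of growth:
compound 1 `COc1cc2c(/C=C3/C(=O)Nc4ccc(Cl)cc43)c(Cl)n(Cc3cc(OC)c(OC)c(OC)c3)c2cc1C` gives 2190 nM
compound 2 `COc1ccc2c(c1)/C(=C\c1c(Cl)n(Cc3cc(OC)c(OC)c(OC)c3)c3cc(C)c(OC)cc13)C(=O)N2` gives 11000 nM
compound 3 `COc1c(/C=C2/C(=O)Nc3ccc(Cl)cc32)c2ccccc2n1-c1ccccc1` gives 6310 nM

The change from compound 1 to compound 2 is methoxy in place of chloro on an aromatic carbon and gave a 5.0-fold higher number from compound 1 to compound 2 (0.70 log units; beyond the scatter). Compound 3 sits on a second core; how that core differs from the core of compound 1 is not broken down here. The values of compound 3 and compound 2 lie within the scatter of each other, whereas the gap from compound 1 to compound 3 is beyond the scatter.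

Compound 4 `COc1ccc2c(c1)/C(=C\c1c(OC)n(-c3ccccc3)c3ccccc13)C(=O)N2` applies the same change to compound 3: methoxy in place of chloro on an aromatic carbon. The surroundings of the place are the same word for word in both pairs, so this is the same change, not merely the same kind. Compound 4 is expected to inhibit growth more weakly than compound 3, with an estimated step of a 4.0-fold higher number from compound 3 to compound 4 (0.60 log units; beyond the scatter), because the same change on the first core produced a 5.0-fold higher number from compound 1 to compound 2 (0.70 log units; beyond the scatter). Among the compounds with values here, since only one earlier instance is known, the range is kept wide.

Estimate for compound 4 in this assay: 25000 nM, expected between 8000 nM and 80000 nM.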

Compound 4, concentration for 50% growth inhibition: 1740 nM
Beside the measured number, compound 4's estimate is 14-fold (1.16 log units) above it; the whole stated range lies above it.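

In this assay, methoxy in place of chloro on an aromatic carbon gave a 3.6-fold lower number from compound 3 to compound 4 (0.56 log units; beyond the scatter), so the direction seen on the first core did not carry over to the second. Set side by side, the two steps run in opposite directions and their gap is real: the same change on two cores in this assay, a 5.0-fold higher number (0.70 log units; beyond the scatter) from compound 1 to compound 2 and a 3.6-fold lower number (0.56 log units; beyond the scatter) from compound 3 to compound 4, 18-fold (1.26 log units) apart, beyond the scatter of two such steps This shows that, within these two pairs, the outcome of the change depends on the core and cannot be read across from one core to the other; it does not show which of the differences between the two cores decides the direction, since each core contributes only a single pair and those cores differ in more than one place.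

Open, going by these compounds, is whether a third core would follow the first, the second or neither. Also open, on these data alone, is how other groups on the same aromatic carbon would behave on each core, such as an amine, a carboxylic acid or a longer ether chain like propoxy.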